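Methoxy on the anilino ring of a thiophene-type series

The compounds below may be only part of what the source reports. "The series", "measured", "known", "first", "only" and "open" are said of these compounds alone.

Measured compounds:
compound 1 `COC(=O)c1c(Nc2ccccc2)sc(C(=O)c2ccc(OC)cc2)c1C` gives 18% in a functional assay, with a stated time of 150 min, tested at 10 ug/mL; on this read-out higher numbers stand for a stronger effect at the one concentration tested and lower numbers for a weaker effect
compound 2 `COC(=O)c1c(Nc2ccc(F)cc2)sc(C(=O)c2ccc(OC)cc2)c1C` gives 14% in this assay
compound 3 `COc1ccc(C(=O)c2sc(Nc3ccccc3)c(C(=O)O)c2C)cc1` gives 24.7% in this assay

Compound 3 gives the largest of the three numbers, yet compound 1 sits within the usual scatter of it, and only compound 2 lies beyond that scatter below it. The two changes that were measured are both small: a number 4 percentage points lower from compound 1 to compound 2 (within the scatter) and a number 6.7 percentage points higher from compound 1 to compound 3 (within the scatter).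

Compound 4 `COc1ccc(Nc2sc(C(=O)c3ccc(OC)cc3)c(C)c2C(=O)O)cc1` has not yet been measured. It differs from compound 3 in one place: methoxy in place of hydrogen on an aromatic carbon. The change from anilino to (4-methoxyphenyl)amino resembles the step in which a fluoro entered the same kind of position, and that step, a number 4 percentage points lower from compound 1 to compound 2 (within the scatter), stayed within the scatter. On that single comparison, the expected outcome in this assay is no step beyond the scatter, with the change a number 0.7 percentage points lower from compound 3 to compound 4 (within the scatter) estimated as close to nothing. Compound 4 is therefore expected to give about 24%, in a range from 12% to 38%.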

Compound 4, a percentage reported as activity, at one concentration (the size of the read-out at that concentration, not a potency): 23.5%
Beside the measured number, compound 4's estimate is 0.5 percentage points above it; low and high end bracket the measured number.
By their numbers in this assay, from the lowest: compounds 2, 1, 4 and 3 (each within the scatter of the next, the first and the last beyond it).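

In this assay the step with methoxy in place of hydrogen, on an aromatic carbon para to a large group, is a number 1.2 percentage points lower from compound 3 to compound 4 (within the scatter), so this position took a group of 2 heavy atoms without a step beyond the scatter. The earlier compounds had shown a change here only for fluoro and only among the methyl esters, as a number 4 percentage points lower from compound 1 to compound 2 (within the scatter), whereas this step extends the same finding to methoxy and to the carboxylic acids. Nothing available here bears on the reason for this result.

Going by these compounds, whether an amine, a hydroxyl or a longer chain such as butoxy would also stay within the scatter at this position remains open. With a single concentration and a single read-out, the compounds shown also leave open whether their potencies differ.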